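The compounds below may be only part of what the source reports. "The series", "measured", "known", "first", "only" and "open" are said of these compounds alone.

Of the compounds shown here, three built on a shared core have so far been tested in a functional assay on PC-12 cells (Rattus norvegicus) for cytotoxicity, read by MTT assay, with stated times of 3 h and 2 h, tested at 5 uM; a lower number here means a weaker effect, a higher number a stronger effect of the compound at the concentration tested. Compound 1, `O=C(CCCCC1CCSS1)NCc1cn(CCCOc2ccc3ccc(=O)oc3c2)nn1`, gives 39.2% in this assay. Compound 2, `O=C(CCCCC1CCSS1)NCc1cn(CCCCOc2ccc3cc(-c4ccc(Cl)c(Cl)c4)c(=O)oc3c2)nn1`, gives 53.2%. Compound 3, `O=C(CCCCC1CCSS1)NCc1cn(CCCCCOc2ccc3cc(-c4ccccc4)c(=O)oc3c2)nn1`, gives 28%, the lowest of the three numbers; its nearest neighbour is compound 1, whose number lies higher by a margin beyond the usual scatter, and compound 2 stands further off again, also beyond the scatter.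

Compound 4, `O=C(CCCCC1CCSS1)NCc1cn(CCCCCOc2ccc3cc(-c4ccc(Cl)c(Cl)c4)c(=O)oc3c2)nn1`, has not yet been measured. It differs from compound 3 in one place: 3,4-dichlorophenyl in place of phenyl on an aromatic carbon. Among the measured compounds shown here, no step between two measured compounds isolates this change, so the expectation must rest on the wider picture. Compound 2 also carries the 3,4-dichlorophenyl group and gives 53.2%, which points toward a higher read-out once the same group enters compound 3. The step of a number 17 percentage points higher from compound 3 to compound 4 (beyond the scatter) is therefore expected to be an increase beyond the scatter. Compound 4 is estimated at 45%, within a range from 30% to 60%.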

Compound 4, a percentage reported as activity, at one concentration (the size of the read-out at that concentration, not a potency): 54.8%
Estimate against measurement, compound 4: 9.8 percentage points below; low and high end bracket the measured number.
By their numbers in this assay, from the lowest: compound 3; then compound 1; then compounds 2 and 4 (each within the scatter of the next).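

Swapping phenyl for 3,4-dichlorophenyl on this aromatic carbon, two atoms from the ring oxygen of the shared core, gives the first clean one-place comparison in the series: in this assay there is a number a number 26.8 percentage points higher from compound 3 to compound 4 (beyond the scatter), a stronger effect at the concentration tested. The change adds two chlorine atoms and no hydrogen-bond donors or acceptors, and compound 2, with the same group, gives 53.2% while compound 4 gives 54.8%, values within the usual scatter of each other. Nothing measured here explains why the step occurs.

On these data alone, it remains open whether both chlorines are needed, as a phenyl carrying a single chlorine would show. Nor can these compounds say how a methoxy group or an amine on that phenyl ring would behave in its place.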